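Methyl to methoxy on the arylamino group of compound 3

The compounds below may be only part of what the source reports. "The series", "measured", "known", "first", "only" and "open" are said of these compounds alone.

Measured so far:
compound 1 `COC(=O)c1c(Nc2ccc(OC)cc2)sc(C(=O)c2ccc(OC)cc2)c1C` gives 20.5%
compound 2 `COc1ccc(C(=O)c2sc(Nc3ccccc3)c(C(=O)O)c2C)cc1` gives 59.5%
compound 3 `COc1ccc(C(=O)c2sc(Nc3ccc(C)cc3)c(C(=O)O)c2C)cc1` is reported as "not active" (no number reported)

These three compounds were tested in a functional assay, with a stated time of 150 min, tested at 30 ug/mL; on this read-out higher numbers stand for a stronger effect at the one concentration tested and lower numbers for a weaker effect. Compound 2 `COc1ccc(C(=O)c2sc(Nc3ccccc3)c(C(=O)O)c2C)cc1` reaches 59.5% in this assay, while compound 1 `COC(=O)c1c(Nc2ccc(OC)cc2)sc(C(=O)c2ccc(OC)cc2)c1C` reaches 20.5%. For compound 3 `COc1ccc(C(=O)c2sc(Nc3ccc(C)cc3)c(C(=O)O)c2C)cc1` no single number exists: in this assay compound 3 is recorded only as "not active" (no number reported), so it stands below both measured compounds without a value of its own. Compound 2 and compound 3 show that a phenylamino group gives a clear read-out whereas the (4-methylphenyl)amino group gives none.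

Compound 4 `COc1ccc(Nc2sc(C(=O)c3ccc(OC)cc3)c(C)c2C(=O)O)cc1` has not yet been measured in this assay. It differs from compound 3 in one place: methoxy in place of methyl on an aromatic carbon. Compound 1 also carries a (4-methoxyphenyl)amino group and gives a low read-out. Since compound 3 has no number, no step size can be computed, but a change from "not active" upward by more than the scatter in this assay seems possible yet uncertain. Compound 4 is expected to give 25%, estimated between 0% and 55%.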

Compound 4, a percentage reported as activity, at one concentration (the size of the read-out at that concentration, not a potency): 41.2%
The estimate for compound 4 lay 16.2 percentage points below the measured number, and the stated range covers the measured number.
By their numbers in this assay, from the lowest: compound 1; then compound 4; then compound 2.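

In this assay the change from (4-methylphenyl)amino to (4-methoxyphenyl)amino separates a compound with no number from one with a clear read-out: compound 3 is recorded only as "not active", whereas compound 4 gives 41.2% at the one concentration tested, so a group para to a large group on this aromatic ring need not abolish the read-out. Methoxy in place of hydrogen at the same place still comes at a cost, with a number 18.3 percentage points lower from compound 2 to compound 4 (beyond the scatter) in this comparison, so among compounds 2, 3 and 4 the unsubstituted phenylamino group gives the highest number, and methoxy recovers only part of it. With the (4-methoxyphenyl)amino group held constant, the free carboxylic acid also reads higher than the methyl ester, with a number 20.7 percentage points higher from compound 1 to compound 4 (beyond the scatter) in that comparison, which ties the read-out to this second place as well as to the arylamino group.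

Why methoxy and methyl differ so sharply remains unexplained, and nothing available bears on the cause. Going by these compounds, how fluoro, hydroxy or a longer chain such as ethoxy would read at this same place also remains open.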